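Cyclopropyl for difluorophenyl on a lactone-triazole series

The compounds below may be only part of what the source reports. "The series", "measured", "known", "first", "only" and "open" are said of these compounds alone.

The series shares a dibenzyloxy lactone carried through a triazole, and its members are compared in a functional assay on HeLa cells (Homo sapiens) for antiproliferative activity, read by MTT assay, with a stated time of 72 h; on this read-out lower numbers stand for stronger inhibition and higher numbers for weaker inhibition. Compound 1 `COc1ccc(-c2cn(C/C=C3\OC(=O)C(OCc4ccccc4)=C3OCc3ccccc3)nn2)cc1` is one of them; in this assay compound 1 gives only a limit, > 100000 nM, and no number. Compound 2 `O=C1O[C@H]([C@@H](O)Cn2cc(-c3cc(F)cc(F)c3)nn2)C(OCc2ccccc2)=C1OCc1ccccc1` gives 40800 nM in this assay, the highest of the two numbers reported here. Compound 3 `O=C1O[C@H]([C@@H](O)Cn2cc(-c3cc(C(F)(F)F)cc(C(F)(F)F)c3)nn2)C(OCc2ccccc2)=C1OCc1ccccc1` gives 35500 nM in this assay, a value that lies within the scatter of compound 2, so the two cannot be ordered.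

Compound 4 `O=C1O[C@H]([C@@H](O)Cn2cc(C3CC3)nn2)C(OCc2ccccc2)=C1OCc1ccccc1` has not yet been measured. It differs from compound 2 in one place: cyclopropyl in place of 3,5-difluorophenyl on an aromatic carbon. Among the measured compounds shown here, no measured pair in this set isolates a change of that kind, so the expectation rests only on where compound 2 stands. With both numbered values already weak, the step from compound 2 to compound 4 is expected to be small, most likely toward a slightly weaker figure, and possibly to end at the limit of this assay; its expected size is a 1.5-fold higher number from compound 2 to compound 4 (0.17 log units; within the scatter). The estimate for compound 4 in this assay is therefore 60000 nM, within a range from 25000 nM to 150000 nM.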

Compound 4, half-maximal inhibitory concentration: 26500 nM
Compound 4: middle estimate off by 2.3-fold (0.35 log units), on the high side; measured number inside the range.
By their numbers in this assay, from the lowest: compounds 4, 3 and 2 (each within the scatter of the next). At a limit, above all of these: compound 1.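

Setting cyclopropyl in place of 3,5-difluorophenyl on the aromatic carbon of the five-membered aromatic ring with 3 nitrogen gives, in this assay, a 1.5-fold lower number from compound 2 to compound 4 (0.19 log units; within the scatter). Among the compounds shown here, every earlier compound carried a phenyl ring at this position, so this step is the first to show that the six-membered aromatic ring can leave, with 8 heavy atoms giving way to 3, without the number moving beyond the scatter. Compound 1 still gives only a limit and no number, and the series stays close to that ceiling: the limit of > 100000 nM in this assay, at which 1 of the 4 values shown sits.

For the compounds shown here, what the compounds leave open is whether any group at this position can move the number beyond the scatter, since the one readable step here does not, and an amine, a carboxylic acid or a longer alkyl chain on the same aromatic carbon would put that to the test. No pair shown differs in one place at the chain joining the lactone to the ring with 3 nitrogen, so the contribution of that chain to the values cannot be read.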